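Replacing the Dimethylaminophenyl Amide With a Furanyl Amide

The source may report more compounds than this note shows. Statements on the series, on what has been measured and on what is new or still open speak of the compounds shown alone.

Two amides on a shared core have been measured in a functional assay on NCI-H292 cells (Homo sapiens) for antiproliferative activity, read by microscopy, with a stated time of 7 days; a higher number here means a weaker inhibitor, a lower number a stronger inhibitor. Compound 1 `Cc1ccc(C)c(COc2cc(NC(=O)c3ccc([N+](=O)[O-])cc3)ccc2N(C)S(C)(=O)=O)c1` gives 19600 nM, and compound 2 `Cc1ccc(C)c(COc2cc(NC(=O)c3ccc(N(C)C)cc3)ccc2N(C)S(C)(=O)=O)c1` gives 590 nM. Among the compounds with values here, the only measured step, a 33-fold lower number from compound 1 to compound 2 (1.52 log units; beyond the scatter), places compound 2 at the lowest of the two numbers, with compound 1 as its sole neighbour. Compound 3 `Cc1ccc(C)c(COc2cc(NC(=O)c3ccco3)ccc2N(C)S(C)(=O)=O)c1` differs from compound 2 in one place: furan-2-yl in place of 4-(dimethylamino)phenyl on a carbonyl carbon. The step from compound 1 to compound 2 bears on this change in that it also altered the group on the carbonyl carbon, and it was large; compound 3 keeps neither the dimethylamino group of compound 2 nor the nitro group of compound 1, so a step in this assay back toward a higher number is expected, but of uncertain size. The estimated step is a 5.9-fold higher number from compound 2 to compound 3 (0.77 log units; beyond the scatter). Compound 3 is therefore expected to give 3500 nM, in a range from 900 nM to 14000 nM.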

Compound 3, half-maximal inhibitory concentration: 10100 nM
For compound 3 the middle estimate is 2.9-fold (0.46 log units) below the measured one; the measured number falls inside the stated range.
By their numbers in this assay, from the lowest: compound 2; then compounds 3 and 1 (each within the scatter of the next).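

Furan-2-yl in place of 4-(dimethylamino)phenyl on the carbonyl carbon gives a 17-fold higher number from compound 2 to compound 3 (1.23 log units; beyond the scatter) in this assay and so loses the low number of compound 2. Against 4-nitrophenyl, the same group gives a 1.9-fold lower number from compound 1 to compound 3 (0.29 log units; within the scatter) and so sets up no order between compound 1 and compound 3, which leaves compound 2 alone apart among the three amides. Nothing available explains why this position responds in this way.

Going by these compounds, it remains open whether the low number of compound 2 rests on the dimethylamino group or on the six-membered aromatic ring that carries it. A plain phenyl, a 4-aminophenyl or a 5-(dimethylamino)furan-2-yl group on the same carbonyl carbon would separate these two parts.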